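Removing a Methyl from a Phenolic Ester

The source may hold more compounds than are shown below. What is called first, only, known or untested is meant among the compounds shown, and "the series" means these compounds.

Two benzoate esters of a shared core were tested for cytotoxicity in a functional assay on K562 cells (Homo sapiens) for cytotoxicity, read by MTT assay, with a stated time of 72 h; a higher number here means a weaker inhibitor, a lower number a stronger inhibitor. Compound 1 `CC1=CC[C@]2(C)[C@@H]([C@@H](OC(=O)c3ccc(O)cc3)C1)[C@](O)(C(C)C)C[C@@H]2O` gives 95000 nM. Compound 2 `COc1ccc(C(=O)O[C@H]2CC(C)=CC[C@@]3(C)CC[C@@](O)(C(C)C)[C@H]23)cc1` gives 67800 nM, the lower of the two numbers, though its gap to compound 1 lies within the usual scatter, so the two cannot be told apart. Compound 3 `CC1=CC[C@@]2(C)CC[C@@](O)(C(C)C)[C@@H]2[C@@H](OC(=O)c2ccc(O)cc2)C1` is compound 2 with one change: hydrogen in place of methyl on an oxygen on an aromatic ring. Within the data shown here, no directly comparable measured pair exists, so the step is expected to stay within the scatter, perhaps toward a slightly higher number, as a 1.2-fold higher number from compound 2 to compound 3 (0.07 log units; within the scatter). Compound 3 is therefore estimated at 80000 nM, within 30000 nM to 200000 nM.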

Compound 3, half-maximal inhibitory concentration: > 100000 nM
Compound 3 was reported as a limit; the forecaster's own chance of this, stated with the estimate: 10%; at least 1.2-fold (0.09 log units) between middle value and limit.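

Swapping methoxy for hydroxy on the aromatic ring can be read only as a floor: an at least 1.4-fold higher number from compound 2 to compound 3 (0.16 log units; that floor lies within the scatter). Taking away the hydroxy on a saturated ring carbon of compound 1 also gives only a floor: an at least 1.0-fold higher number from compound 1 to compound 3 (0.02 log units; that floor lies within the scatter). The value of compound 3 is a limit and not a number, so neither step shows a real change at these positions: the limit of > 100000 nM in this assay, at which 1 of the 3 values shown sits.

As far as these compounds go, how far compound 3 truly lies from compound 2 stays open. So does whether an amine or a carboxylic acid at the place of the methoxy would change the number.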